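The source may report more compounds than this note shows. Statements on the series, on what has been measured and on what is new or still open speak of the compounds shown alone.

Compound 1 `CCCC(=O)N1CC2CC(C1)N2` is the reference point here. In an assay on SH-EP1 cells for agonist activity at Neuronal acetylcholine receptor; alpha4/beta2 (Homo sapiens), read by FLIPR and calcium flux (on this read-out higher numbers stand for an effect only at larger amounts of compound and lower numbers for an effect already at smaller amounts), compound 1 gives 850 nM, the lowest number among the three measured compounds. Compound 3 `O=C(C1CC=CC1)N1CC2CC(C1)N2` gives 17000 nM in this assay, and compound 2 `CC(C)C(=O)N1CC2CC(C1)N2` gives 20000 nM, both well above compound 1 and both beyond the scatter.

Only one single-point step is defined among these: a 24-fold higher number from compound 1 to compound 2 (1.37 log units; beyond the scatter), an isopropyl in place of propyl on a carbonyl carbon. Compound 3 carries a ring on the same carbonyl carbon, and its value likewise sits far above that of compound 1.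

The unmeasured compound 4 `C[C@H]1C[C@H]1C(=O)N1CC2CC(C1)N2` differs from compound 1 in one place: 2-methylcyclopropyl in place of propyl on a carbonyl carbon. Like the change to compound 2 and the group seen in compound 3, this replaces the propyl on the carbonyl carbon with something other than a plain chain, here a small ring. Among the compounds with values here, the one measured step that bears on it, from compound 1 to compound 2, raised the number strongly, and compound 3 points the same way. A step upward in this assay, clearly beyond the scatter, is therefore expected: a 7.1-fold higher number from compound 1 to compound 4 (0.85 log units; beyond the scatter). The estimate for compound 4 in this assay is 6000 nM, within a range from 1500 nM to 25000 nM.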

Compound 4, half-maximal effective concentration: 5800 nM
Beside the measured number, compound 4's estimate is 1.0-fold (0.01 log units) above it, and the stated range covers the measured number.
By their numbers in this assay, from the lowest: compound 1; then compound 4; then compounds 3 and 2 (each within the scatter of the next).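

Within this assay the change to 2-methylcyclopropyl on the carbonyl carbon gives a 6.8-fold higher number from compound 1 to compound 4 (0.83 log units; beyond the scatter) and so still does not match the plain propyl, yet compared with the branched group it gives a 3.4-fold lower number from compound 2 to compound 4 (0.54 log units; beyond the scatter) and so recovers part of what isopropyl lost. This position therefore does not respond in an all-or-nothing way: both replacements of propyl raise the number, but by clearly different amounts, even though neither group is a straight chain. Where the earlier compounds offered a single step at this carbonyl carbon, there is now an order of three, with compound 1 lowest, then compound 4, then compound 2, and each gap beyond the scatter.

From the compounds shown here alone, it remains open whether the three-membered ring, its methyl or its two defined stereocentres set the place of compound 4, and a plain cyclopropyl or a butyl chain on the same carbonyl carbon would help to separate these possibilities. Nothing in the data shown explains why these groups differ in this way.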